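The compounds below may be only part of what the source reports. "The series", "measured", "known", "first", "only" and "open" are said of these compounds alone.

Values in an ADME assay on the whole organism (Rattus norvegicus) for metabolic stability (a lower number here means that the compound disappears faster, a higher number that the compound lasts longer), so far
- compound 1 `CC(C)(NC(=O)c1cnc(-c2cscn2)nc1O)c1ccccc1` gives 2.9 h
- compound 2 `CC(C)(NC(=O)c1cnc(-n2cccn2)nc1O)c1ccccc1` gives 4.2 h
- compound 3 `CC(C)(NC(=O)c1cnc(-n2cc(C(=O)O)cn2)nc1O)c1ccccc1` gives 2.1 h

Compound 3 stands within the scatter of both others, with a 1.4-fold lower number from compound 1 to compound 3 (0.14 log units; within the scatter) and a 2.0-fold lower number from compound 2 to compound 3 (0.30 log units; within the scatter) as its steps. Compound 4 `CC(C)(NC(=O)c1cnc(-c2cc(C(=O)O)ccn2)nc1O)c1ccccc1` changes the ring that carries the carboxy group: 4-carboxypyridin-2-yl in place of 4-carboxy-1H-pyrazol-1-yl on an aromatic carbon, with 4-carboxypyridin-2-yl in place of 4-carboxy-1H-pyrazol-1-yl on an aromatic carbon. The nearest measured ring swap at this place is a 1.4-fold higher number from compound 1 to compound 2 (0.16 log units; within the scatter), which also stays within the scatter. Among the compounds with values here, no measured compound carries the new group, so the evidence is indirect. No step beyond the scatter is therefore expected in this assay, and the estimated step is a 1.1-fold higher number from compound 3 to compound 4 (0.06 log units; within the scatter) here. Compound 4 is expected at 2.4 h, with an estimated range of 1 h to 5 h.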

Compound 4, half-life: 0.23 h
Beside the measured number, compound 4's estimate is 10-fold (1.02 log units) above it; the whole stated range lies above it.
By their numbers in this assay, from the lowest: compound 4; then compounds 3, 1 and 2 (each within the scatter of the next).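

In this assay, within the data shown here, this position turns out to be sensitive to the ring placed on it: 4-carboxypyridin-2-yl in place of 4-carboxy-1H-pyrazol-1-yl gives a 9.1-fold lower number from compound 3 to compound 4 (0.96 log units; beyond the scatter), the first step here beyond the scatter. Against the two rings without a carboxy group the steps are similar, an 18-fold lower number from compound 2 to compound 4 (1.26 log units; beyond the scatter) and a 13-fold lower number from compound 1 to compound 4 (1.10 log units; beyond the scatter), yet compound 3 shows that a carboxy group alone does not give so low a number. No measurement at hand offers a reason for this drop. Still open, from the compounds shown here alone, is whether the six-membered ring alone gives such a low number or needs its carboxy group; a plain pyridin-2-yl or a 4-aminopyridin-2-yl would separate the two.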